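A tail swap on the shared core and what it might bring

The source may hold more compounds than are shown below. What is called first, only, known or untested is meant among the compounds shown, and "the series" means these compounds.

Compound 3 `CC(C)(C)c1ccc(C(=O)N2CCC3(CC2)C(=O)N(CC(=O)NCCCCCNS(C)(=O)=O)CN3c2ccccc2)cc1` gives 5500 nM in an assay on HEK293 cells for displacement of a labelled ligand from NPC1-like intracellular cholesterol transporter 1 (Homo sapiens) (a higher number here means a weaker inhibitor, a lower number a stronger inhibitor), the lower of the two numbers recorded here, with compound 1 `CC(C)(C)OC(=O)NCCCCCNC(=O)CN1CN(c2ccccc2)C2(CCN(C(=O)c3ccc(C(C)(C)C)cc3)CC2)C1=O` giving 13700 nM. For compound 2 `CC(C)(C)OC(=O)NCCCCNC(=O)CN1CN(c2ccccc2)C2(CCN(C(=O)c3ccc(C(C)(C)C)cc3)CC2)C1=O` the entry in this assay reads "not determined" (no result reported). Within the data shown here, the one step available, a 2.5-fold lower number from compound 1 to compound 3 (0.40 log units; beyond the scatter), changes only the end of the chain that hangs off the shared core, and it is modest. Compound 4 `CC(C)(C)c1ccc(C(=O)N2CCC3(CC2)C(=O)N(CC(=O)N2CCCCC2CCO)CN3c2ccccc2)cc1` carries a different change at that same chain: 2-(2-hydroxyethyl)piperidin-1-yl in place of (5-(methanesulfonamido)pentyl)amino on a carbonyl carbon. Among the measured compounds shown here, no measured pair shows this particular exchange, so the only guidance is that the single known change on this chain, from compound 1 to compound 3, moved the number modestly. Compound 4 is therefore expected to stay within a modest range of compound 3, with a 1.3-fold higher number from compound 3 to compound 4 (0.10 log units; within the scatter) as the expected step and no clear direction favoured. The estimate for compound 4 is 7000 nM in this assay, with a likely range from 2000 nM to 25000 nM.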

Compound 4, half-maximal inhibitory concentration: 6100 nM
Compound 4: middle estimate off by 1.1-fold (0.06 log units), on the high side; the range from low to high includes it.
By their numbers in this assay, from the lowest: compounds 3 and 4 (each within the scatter of the next); then compound 1.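

In this assay, the change on this carbonyl carbon gives a 1.1-fold higher number from compound 3 to compound 4 (0.04 log units; within the scatter). The step from compound 1 to compound 3 altered only the end of the chain, whereas here the whole (5-(methanesulfonamido)pentyl)amino group gives way to 2-(2-hydroxyethyl)piperidin-1-yl, so a chain with no ring and a six-membered non-aromatic ring read alike at this position. The methanesulfonamide is therefore not needed for a number at this level, since compound 4 has none, and no measurement shown explains why the two groups read alike.

As far as these compounds go, it remains open whether a piperazine ring or a chain ending in a carboxylic acid on this carbonyl carbon would move the number beyond the scatter. From the compounds shown here alone, it is equally open whether plain piperidin-1-yl, without the hydroxyethyl arm, would read the same.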